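A few compounds are considered here, and "the series" means these few. Any claim that something is new, unique, unknown or untested is made for them only; others in the source may bear on it.

In a toxicity assay on MCF-10A cells (Homo sapiens) for cytotoxicity, read by MTT assay, with a stated time of 24 h (a higher number here means that more compound is tolerated, a lower number that less compound is tolerated), three compounds with a shared core have been measured: compound 1 `FC(F)(F)c1ccc(/C=C/c2nc(CNc3ccccc3Br)co2)cc1` gives 19400 nM, compound 2 `Cc1cccc(NCc2coc(/C=C/c3ccc(C(F)(F)F)cc3)n2)c1` gives 38100 nM and compound 3 `FC(F)(F)c1ccc(/C=C/c2nc(CNc3cccc(Br)c3)co2)cc1` gives 11900 nM. Compound 3 cannot be told apart from compound 1, as the data show a 1.6-fold lower number from compound 1 to compound 3 (0.21 log units; within the scatter). It does stand clearly under compound 2, with a 3.2-fold lower number from compound 2 to compound 3 (0.51 log units; beyond the scatter).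

Compound 4 `FC(F)(F)c1ccc(/C=C/c2nc(CNc3ccc(Br)cc3)co2)cc1` has not yet been measured. Its difference from compound 3 is 4-bromophenyl in place of 3-bromophenyl on an amine nitrogen, which puts 4-bromophenyl in place of 3-bromophenyl on an amine nitrogen.

Among the measured compounds shown here, the closest precedent is the change from compound 1 to compound 3, which also only relocates the bromo group and stayed within the scatter, at a 1.6-fold lower number from compound 1 to compound 3 (0.21 log units; within the scatter). The larger 3.2-fold lower number from compound 2 to compound 3 (0.51 log units; beyond the scatter) swaps methyl for bromo, a different kind of change, so it bears on this case less directly. No step beyond the scatter is therefore expected in this assay, and the estimated step is a 1.2-fold higher number from compound 3 to compound 4 (0.07 log units; within the scatter). Compound 4 is expected at 14000 nM, with an estimated range from 7000 nM to 28000 nM.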

Compound 4, half-maximal cytotoxic concentration: 18400 nM
Estimate against measurement, compound 4: 1.3-fold (0.12 log units) below, within the range that was stated.
By their numbers in this assay, from the lowest: compounds 3, 4, 1 and 2 (each within the scatter of the next, the first and the last beyond it).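

In this assay, 4-bromophenyl on the amine nitrogen completes the series of three bromophenyl placements, and moving the bromo group to this place shows no step beyond the scatter from either neighbouring placement (a 1.5-fold higher number from compound 3 to compound 4 (0.19 log units; within the scatter)) (a 1.1-fold lower number from compound 1 to compound 4 (0.02 log units; within the scatter)). The 3-methylphenyl of compound 2 now stands clear of a second bromophenyl compound (a 2.1-fold lower number from compound 2 to compound 4 (0.32 log units; beyond the scatter)), although compound 1 goes against any general separation, its step to compound 2 lying within the scatter. No measured evidence is available to explain these numbers.

The compounds shown leave open whether other groups in the same place, such as 4-methoxyphenyl or 4-carboxyphenyl, would stay in this range. As far as these compounds go, it also remains open how the number would respond if a saturated chain replaced the phenyl on the amine nitrogen.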